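Side-chain change from compound 2 to compound 3

A few compounds are considered here, and "the series" means these few. Any claim that something is new, unique, unknown or untested is made for them only; others in the source may bear on it.

Going by the values given here, in a functional assay on HCT-116 cells (Homo sapiens) for inhibition, read by MTT assay, with a stated time of 48 h (on this read-out lower numbers stand for stronger inhibition and higher numbers for weaker inhibition), compound 2 (`COc1ccc(N(C)c2nc(C)nc3ccccc23)cc1C(=O)OCCCC[Se]C#N`) gives 662 nM, the lower of the two numbers so far, while compound 1 (`COc1ccc(N(C)c2nc(C)nc3ccccc23)cc1OCCCCCC[Se]C#N`) gives 6180 nM. Compound 3 (`COc1ccc(N(C)c2nc(C)nc3ccccc23)cc1OCC[Se]C#N`) is still unmeasured. It differs from compound 2 as follows: a group of 6 heavy atoms (3 carbon, 1 nitrogen, 1 oxygen, 1 selenium; no ring) in place of a group of 10 heavy atoms (6 carbon, 1 nitrogen, 2 oxygen, 1 selenium; no ring), on an aromatic carbon. Among the compounds with values here, the one measured step bearing on this, a 9.3-fold lower number from compound 1 to compound 2 (0.97 log units; beyond the scatter), involves the same place, and compound 3 shares the ether link of compound 1. On these data alone, a higher number is therefore expected in this assay, although the shorter chain is untested. The expected step is a 3.8-fold higher number from compound 2 to compound 3 (0.58 log units; beyond the scatter). For compound 3 the estimated value is 2500 nM, with an expected range of 700 nM to 9000 nM.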

Compound 3, half-maximal inhibitory concentration: 18 nM
Compound 3: the middle estimate sits 140-fold (2.14 log units) above what was measured; the whole stated range lies above it.
By their numbers in this assay, from the lowest: compound 3; then compound 2; then compound 1.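

In this assay the ether link does not by itself go with the weaker number: shortening the chain on that link gives a 340-fold lower number from compound 1 to compound 3 (2.54 log units; beyond the scatter) and so chain length at this position has a large influence on the read-out. The ester-bearing side chain also loses its lead, with a 37-fold lower number from compound 2 to compound 3 (1.57 log units; beyond the scatter) as the step, although link and chain length change together there. No measured evidence explains either step.

On these data alone, how ester and ether compare at equal chain length stays open. So does whether an amide link would keep the low number.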